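Changing the Aryl Group on the Sulfonyl Sulfur

This account rests on a few compounds, and the source may have more. Where it says the series, first, only, none or still open, it means among the compounds named here.

Of the compounds shown here, three sharing one core have been tested in an assay on cells for inhibition of HSP60/HSP10 (Homo sapiens), with a stated time of 60 min; on this read-out higher numbers stand for weaker inhibition and lower numbers for stronger inhibition. Compound 1 `Cc1ccccc1S(=O)(=O)Nc1ccc2oc(-c3ccccc3)nc2c1` gives > 100000 nM, which is a limit of the assay rather than a number. Compound 2 `C=Cc1ccc(S(=O)(=O)Nc2ccc(-c3nc4ccccc4o3)cc2)cc1` likewise gives > 100000 nM, again only a limit. Compound 3 `O=S(=O)(Nc1ccc(-c2nc3ccccc3o2)cc1)c1ccc(C(F)(F)F)cc1` gives 50000 nM, a true number. Going by the values given here, the single step that can be measured is an at least 2.0-fold lower number from compound 2 to compound 3 (0.30 log units; that floor lies within the scatter); its floor lies inside the usual scatter, so it shows no change that can be trusted. This is reinforced by the limit of > 100000 nM in this assay, at which 2 of the 3 values shown sit, which caps two of the three results and hides how far apart they really are.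

Compound 4 `Cc1cccc(S(=O)(=O)Nc2ccc(-c3nc4ccccc4o3)cc2)c1` differs from compound 2 in one place: 3-methylphenyl in place of 4-vinylphenyl on a sulfonyl sulfur. Among the compounds with values here, no measured step involves a 3-methylphenyl on this sulfur. Compound 1 does carry a methyl, but on a different ring and with a different attachment of the core, and it shows only a limit in this assay. Within the data shown here, the only step on this ring, from compound 2 to compound 3, stayed within the scatter.

Compound 4 is therefore expected to sit near 100000 nM, somewhere between 40000 nM and 300000 nM. That expectation corresponds to a number no higher from compound 2 to compound 4 (the limit leaves the size open), with a good chance that only a limit is reported.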

Compound 4, half-maximal inhibitory concentration: > 100000 nM
Compound 4 gave a limit, no number (the forecaster's own chance of this, stated with the estimate: 60%); the middle value sits exactly at the limit.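

Compound 2 and compound 4 each give only a limit rather than a number, so no step between them can be read, because both sit at the same cap: the limit of > 100000 nM in this assay, at which 3 of the 4 values shown sit.

What the compounds shown leave open is how far apart 3-methylphenyl and 4-vinylphenyl on the sulfonyl sulfur truly lie in this assay.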